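From pyridin-2-yl to 4-cyclopropylphenyl on a shared core

A few compounds are considered here, and "the series" means these few. Any claim that something is new, unique, unknown or untested is made for them only; others in the source may bear on it.

- compound 1 `COc1ccccc1N1C(=O)CSC1c1cc(F)cc(C(=O)NCCCCc2ccccc2)c1` gives 10000 nM
- compound 2 `C#Cc1cc(C(=O)NCCCCc2ccccc2)cc(C2SCC(=O)N2c2ccccc2OC)c1` gives 10000 nM
- compound 3 `O=C(NCCCCc1ccccc1)c1cccc(C2SCC(=O)N2c2ccccn2)c1` gives 20000 nM

All three values come from a physicochemical assay for solubility, read by turbidimetry, measured as kinetic solubility, at pH 7.4; a higher number here means a more soluble compound, a lower number a less soluble compound. The value of compound 3 lies within the scatter of both compound 1 and compound 2. Compound 4 `O=C(NCCCCc1ccccc1)c1cccc(C2SCC(=O)N2c2ccc(C3CC3)cc2)c1` keeps the core of compound 3 and changes one group: 4-cyclopropylphenyl in place of pyridin-2-yl on an amide-type nitrogen in a ring. Among the compounds with values here, the only measured step, no change at the digits printed from compound 1 to compound 2 (within the scatter), concerns a group on an aromatic carbon, not on the amide-type nitrogen, so it offers little guidance. Within the data shown here, with no measured step at this place, the estimate is uncertain, and a fall beyond the scatter is expected. In this assay the expected step is a 3.3-fold lower number from compound 3 to compound 4 (0.52 log units; beyond the scatter). Compound 4 is estimated at 6000 nM, with an expected range of 2000 nM to 20000 nM.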

Compound 4, solubility: 2000 nM
The estimate for compound 4 lay 3.0-fold (0.48 log units) above the measured number; the measured number falls inside the stated range.
By their numbers in this assay, from the lowest: compound 4; then compounds 1, 2 and 3 (each within the scatter of the next).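

The aryl group on the amide-type nitrogen in a ring can clearly move the reading: in this assay, 4-cyclopropylphenyl in place of pyridin-2-yl gives a 10-fold lower number from compound 3 to compound 4 (1.00 log units; beyond the scatter), the first step measured at this position. This single swap removes the ring nitrogen and adds the three-membered ring together, so the two changes cannot be separated. Nothing measured here explains the step. Still open, going by these compounds, is where plain phenyl or a pyridin-2-yl carrying cyclopropyl would fall, and whether an amine or a carboxylic acid on this ring would raise the number.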